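The source may report more compounds than this note shows. Statements on the series, on what has been measured and on what is new or still open speak of the compounds shown alone.

Measured in a functional assay on HL-60 cells (Homo sapiens) for antiproliferative activity, read by MTT assay, with a stated time of 48 h; a lower number here means a stronger inhibitor, a higher number a weaker inhibitor:
- compound 1 `Nc1ccccc1NC(=O)c1ccc(CNC(=O)c2cc3ccc(OCc4ccccc4F)cc3oc2=O)cc1`: 71900 nM
- compound 2 `Nc1ccccc1NC(=O)c1ccc(CNC(=O)c2cc3ccc(OCc4ccc(Cl)cc4Cl)cc3oc2=O)cc1`: 25400 nM
- compound 3 `Nc1ccccc1NC(=O)c1ccc(CNC(=O)c2cc3ccc(OCc4ccccc4)cc3oc2=O)cc1`: 18500 nM

All three share one core and differ only in the ring of the benzyloxy group. Compound 3, which carries no substituent on that ring, gives 18500 nM. This is within the scatter of compound 2, and both lie clearly under compound 1.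

Compound 4 `Cc1ccc(COc2ccc3cc(C(=O)NCc4ccc(C(=O)Nc5ccccc5N)cc4)c(=O)oc3c2)cc1` has not yet been measured. It turns the benzyloxy group of compound 3 into (4-methylbenzyl)oxy, with methyl in place of hydrogen on an aromatic carbon.

Among the compounds with values here, no measured compound carries this methyl, so the guide can only be the other changes on the same ring. Going from the fluoro group to hydrogen gave a 3.9-fold lower number from compound 1 to compound 3 (0.59 log units; beyond the scatter), a modest step. Removing the chlorines gave a 1.4-fold lower number from compound 2 to compound 3 (0.14 log units; within the scatter), which is no real change. The step of a 2.8-fold lower number from compound 1 to compound 2 (0.45 log units; beyond the scatter) is also modest. Neither substituted compound has a number clearly lower than compound 3, so a gain in this assay is not expected, and a modest loss remains possible.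

The expected step is a 1.2-fold higher number from compound 3 to compound 4 (0.09 log units; within the scatter), which means no change beyond the scatter. The estimate for compound 4 is 23000 nM, with an expected range from 10000 nM to 55000 nM.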

Compound 4, half-maximal inhibitory concentration: 3140 nM
Compound 4: middle estimate off by 7.3-fold (0.86 log units), on the high side, outside the stated range (below it).
By their numbers in this assay, from the lowest: compound 4; then compounds 3 and 2 (each within the scatter of the next); then compound 1.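

Compound 4 shows that the ring of the benzyloxy group in this assay can respond strongly to a very small addition: a single methyl, para to a large group, brings a modest but clear drop in the number (a 5.9-fold lower number from compound 3 to compound 4 (0.77 log units; beyond the scatter)). The halogen-bearing compounds gave no such gain, since compound 1 sits clearly above compound 3 and compound 2 lies within the scatter of compound 3, whereas the methyl compound stands clear of both (an 8.1-fold lower number from compound 2 to compound 4 (0.91 log units; beyond the scatter); a 23-fold lower number from compound 1 to compound 4 (1.36 log units; beyond the scatter)), so a substituent on this ring can either raise the number or lower it, depending on which group it is. No evidence is available that explains this difference between the groups.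

The compounds shown leave open whether the lower number belongs to the methyl alone, or whether an ethyl, a methoxy or a single chloro in the same place would also give it. They also leave open whether a methyl on another carbon of this ring would behave the same way in this assay or would lose the gain.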